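A few compounds are considered here, and "the series" means these few. Any claim that something is new, unique, unknown or untested is made for them only; others in the source may bear on it.

Among the measured compounds shown here, compound 1 `Cc1ccc(-c2nn(-c3ccccc3)cc2-c2nc3ccccc3n2C(=O)c2ccc(Cl)cc2)cc1` gives the highest of the three numbers so far in an ADME assay on HEK-293T cells (Homo sapiens) for cytotoxicity, read by MTT assay, with a stated time of 24 h (on this read-out higher numbers stand for lower toxicity in this test and lower numbers for higher toxicity in this test), where compound 1 gives 216000 nM. Compound 2 `Cc1ccc(-c2nn(-c3ccccc3)cc2-c2nc3ccccc3n2C(=O)c2cncc(C)c2)cc1` in this assay gives 155000 nM, and compound 3 `Cc1cncc(C(=O)n2c(-c3cn(-c4ccccc4)nc3-c3ccc(C(F)(F)F)cc3)nc3ccccc32)c1` gives 123000 nM. The two measured steps among them are small: there is a 1.4-fold lower number from compound 1 to compound 2 (0.14 log units; within the scatter), and there is a 1.3-fold lower number from compound 2 to compound 3 (0.10 log units; within the scatter). Compound 4 `Cc1ccc(-c2nn(-c3ccccc3)cc2-c2nc3ccccc3n2C(=O)c2ccncc2)cc1` has not yet been measured in this assay. It differs from compound 1 in one place: pyridin-4-yl in place of 4-chlorophenyl on a carbonyl carbon. For the measured compounds named here, the step that bears on this change is the one from compound 1 to compound 2, where a different ring with one nitrogen also entered on the carbonyl carbon in place of 4-chlorophenyl and the number moved by only a 1.4-fold lower number from compound 1 to compound 2 (0.14 log units; within the scatter). The step from compound 2 to compound 3 changed a different part of the molecule and also stayed within the scatter. From this, no step beyond the scatter is expected for compound 4 in this assay, and if anything a slightly lower number is expected, following compound 1 with its 216000 nM. Compound 4 is therefore estimated at 170000 nM in this assay, with a range from 90000 nM to 320000 nM, which is expected to amount to a 1.3-fold lower number from compound 1 to compound 4 (0.10 log units; within the scatter).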

Compound 4, half-maximal cytotoxic concentration: 154000 nM
The estimate for compound 4 lay 1.1-fold (0.04 log units) above the measured number; measured number inside the range.
By their numbers in this assay, from the lowest: compounds 3, 4, 2 and 1 (each within the scatter of the next).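

In this assay, a second ring with a nitrogen on the carbonyl carbon behaves as the first did: there is a 1.4-fold lower number from compound 1 to compound 4 (0.15 log units; within the scatter) and so, for pyridin-4-yl as for 5-methylpyridin-3-yl, the exchange of 4-chlorophenyl stays within the scatter. The two rings with a hetero atom can now also be set directly against each other, and there is a 1.0-fold lower number from compound 2 to compound 4 (0.00 log units; within the scatter) with the methyl group gone and the ring nitrogen placed differently, so this exchange also stays within the scatter. Across these three groups on the carbonyl carbon, the read-out does not separate the ring of carbon only from the rings with a hetero atom, and nothing at hand accounts for these numbers.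

The compounds shown leave open whether a group on this carbonyl carbon that is not an aromatic ring, such as an amine or a longer alkyl chain, would give a step beyond the scatter. They also leave open whether a carboxylic acid on the pyridin-4-yl ring would do so.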